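The source may hold more compounds than are shown below. What is called first, only, known or untested is meant among the compounds shown, and "the series" means these compounds.

Measured so far:
compound 1 `COc1cc(-c2cc(/C=C/C(=O)c3ccc(Cl)c(Cl)c3)[nH]n2)cc(OC)c1OC`: 92%
compound 2 `COc1ccc(-c2cc(/C=C/C(=O)c3cc(OC)c(OC)c(OC)c3)[nH]n2)cc1OC`: 89%

In a functional assay on NCI-H522 cells (Homo sapiens) for cytotoxicity, read by sulforhodamine B assay, with a stated time of 48 h, tested at 0.01 uM (a lower number here means a stronger effect, a higher number a weaker effect of the compound at the concentration tested), compound 1 gives 92%, the higher of the two numbers; compound 2 gives 89%, which lies within the scatter of compound 1, so the two are not distinguished. Compound 3 `COc1ccc(C(=O)/C=C/c2cc(-c3cc(OC)c(OC)c(OC)c3)n[nH]2)cc1OC` awaits measurement in this assay. It differs from compound 1 by 3,4-dimethoxyphenyl in place of 3,4-dichlorophenyl on a carbonyl carbon. Within the data shown here, no step between measured compounds is available to set the size of this change. Compound 2, which gives 89%, is built from the same groups as compound 3, so the step of a number 2 percentage points lower from compound 1 to compound 3 (within the scatter) is expected to stay within the scatter. Compound 3 is estimated at 90%, range 78% to 100%.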

Compound 3, a percentage reported as activity, at one concentration (the size of the read-out at that concentration, not a potency): 83%
Compound 3: middle estimate off by 7 percentage points, on the high side; the measured number falls inside the stated range.
By their numbers in this assay, from the lowest: compounds 3, 2 and 1 (each within the scatter of the next).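

In this assay, 3,4-dimethoxyphenyl in place of 3,4-dichlorophenyl on a carbonyl carbon gives a number 9 percentage points lower from compound 1 to compound 3 (within the scatter), the first step read at this position. This place therefore accepts a swap from the two chlorine atoms to the two oxygen-bearing methoxy groups, with their hydrogen-bond acceptors, without a change beyond the scatter. Nothing at hand bears on why these two groups are not separated.

Open, as far as these compounds go, is whether a basic amine or a carboxylic acid on this carbonyl carbon would separate from these two aryl groups. Also open, from the compounds shown here alone, is whether a simple unsubstituted phenyl would do so.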